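Swapping the charged ring end of a long chain on a fibrosis reporter

The source may report more compounds than this note shows. Statements on the series, on what has been measured and on what is new or still open speak of the compounds shown alone.

Three compounds share one core and one long chain, and differ at the charged ring that ends the chain or at the substituent on the aromatic ring next to the chain's oxygen. Compound 1 `Cc1cc(-n2cc(C(=O)Nc3cc(F)cc(F)c3)c(=O)c3ccc(N(C)C)nc32)ccc1OCCCCCCC[N+]1(C)CCN(C)CC1` carries a six-membered ring with two nitrogens at the chain end. In an assay on LX2 cells for inhibition of COL1A1 promoter (Homo sapiens), read by a luciferase reporter, with a stated time of 24 h, tested at 50 uM (a lower number here means a weaker effect, a higher number a stronger effect of the compound at the concentration tested), compound 1 gives 32%. Compound 3 `CC[N+]1(CCCCCCCOc2ccc(-n3cc(C(=O)Nc4cc(F)cc(F)c4)c(=O)c4ccc(N(C)C)nc43)cc2C)CCCC1` keeps everything else but has a five-membered ring with one nitrogen there. In this assay compound 3 gives 82.5%. That change, (a group of 7 heavy atoms (6 carbon, 1 nitrogen; one five-membered non-aromatic ring with 1 hetero atom) in place of a group of 8 heavy atoms (6 carbon, 2 nitrogen; one six-membered non-aromatic ring with 2 hetero atoms), on a saturated chain carbon, seven bonds along the chain from an oxygen on an aromatic ring), made a step of a number 50.5 percentage points higher from compound 1 to compound 3 (beyond the scatter).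

Compound 2 `CN1CC[N+](C)(CCCCCCCOc2ccc(-n3cc(C(=O)Nc4cc(F)cc(F)c4)c(=O)c4ccc(N(C)C)nc43)c(Cl)c2)CC1` has the same chain end as compound 1 but a different aromatic substituent; the difference between the two cores is not broken down here. In this assay compound 2 is reported as "not active" (no number reported), with no number given.

Compound 4 `CC[N+]1(CCCCCCCOc2ccc(-n3cc(C(=O)Nc4cc(F)cc(F)c4)c(=O)c4ccc(N(C)C)nc43)c(Cl)c2)CCCC1` is not yet measured. From compound 2 it arises by a group of 7 heavy atoms (6 carbon, 1 nitrogen; one five-membered non-aromatic ring with 1 hetero atom) in place of a group of 8 heavy atoms (6 carbon, 2 nitrogen; one six-membered non-aromatic ring with 2 hetero atoms), on a saturated chain carbon, seven bonds along the chain from an oxygen on an aromatic ring, the same change that turned compound 1 into compound 3, at the same place on the chain. Because compound 1 moved to compound 3 by a number 50.5 percentage points higher from compound 1 to compound 3 (beyond the scatter), a gain of similar size is expected for compound 4, though it starts from a compound with no reported number, so the outcome is uncertain. In this assay compound 4 is estimated at 40%, expected to fall between 10% and 70%.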

Compound 4, a percentage reported as inhibition, at one concentration (the size of the read-out at that concentration, not a potency): "not active" (no number reported)
No number was reported for compound 4; there is nothing to compare the estimate with.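

Within the data shown here, compound 2 and compound 4 are both reported without a number in this assay, so no step between them can be read. No measurement shown here offers an explanation for this result. From the compounds shown here alone, it remains open whether the five-membered ring at the chain end changes the read-out on the core of compound 2 as it did from compound 1 to compound 3, or what separates these two cores.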